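From 4-methylphenyl to 3-chlorophenyl in a weak series

A few compounds are considered here, and "the series" means these few. Any claim that something is new, unique, unknown or untested is made for them only; others in the source may bear on it.

In a functional assay on SGC-7901 cells (Homo sapiens) for antiproliferative activity, read by MTT assay, with a stated time of 24 h (a higher number here means a weaker inhibitor, a lower number a stronger inhibitor), compound 1 `O=C(NNc1ccccc1Cl)c1ccccc1NS(=O)(=O)c1cnc(O)nc1O` gives > 20000 nM, and this is a limit of the assay, not a number. In this assay, within the data shown here, compound 2 `Cc1ccc(C(=O)NNC(=O)c2ccccc2NS(=O)(=O)c2cnc(O)nc2O)cc1` gives 15500 nM, the only actual number so far. Compound 3 `O=C(NNC(=O)c1ccccc1NS(=O)(=O)c1cnc(O)nc1O)c1cccc(Cl)c1` differs from compound 2 in one group, with 3-chlorophenyl in place of 4-methylphenyl on a carbonyl carbon. Among the measured compounds shown here, only one measured step exists as a guide, an at least 1.2-fold lower number from compound 1 to compound 2 (0.11 log units; that floor lies within the scatter). It exchanges different groups from those changing here, so it gives only weak guidance on size or direction. No step beyond the scatter is therefore expected in this assay, and the estimate stays close to compound 2, which gives 15500 nM. The expected change is a 1.1-fold lower number from compound 2 to compound 3 (0.04 log units; within the scatter). For compound 3 the estimate is 14000 nM, with an expected range of 7000 nM to 26000 nM.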

Compound 3, half-maximal inhibitory concentration: 1820 nM
Beside the measured number, compound 3's estimate is 7.7-fold (0.89 log units) above it; the whole stated range lies above it.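

In this assay, the group on the carbonyl carbon clearly matters: 3-chlorophenyl in place of 4-methylphenyl, with the same heavy-atom count and the same kind of aromatic ring, gives an 8.5-fold lower number from compound 2 to compound 3 (0.93 log units; beyond the scatter), a step beyond the scatter that the earlier pair did not show. Set against the other compound in the series, (3-chlorophenyl)carbonyl in place of 2-chlorophenyl gives an at least 10-fold lower number from compound 1 to compound 3 (1.04 log units; beyond the scatter). That size is only a floor, since compound 1 carries a limit of the assay and not a number: the limit of > 20000 nM in this assay, at which 1 of the 3 values shown sits.

The compounds shown do not tell whether the stronger result follows from the chlorine, from where it sits on the ring, or from the loss of the methyl. On these data alone, how 4-chlorophenyl, 3-methylphenyl, or a phenyl ring carrying an amine or a carboxylic acid would read on this carbonyl carbon also remains open.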